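Ring exchange at the carbon double-bonded to nitrogen

This account rests on a few compounds, and the source may have more. Where it says the series, first, only, none or still open, it means among the compounds named here.

In a functional assay on SW 1116 cells (Homo sapiens) for cytotoxicity, read by MTT assay, with a stated time of 48 h (on this read-out lower numbers stand for stronger inhibition and higher numbers for weaker inhibition), compound 3 `COc1cccc(/C=N/NC(=O)CSc2nnc(-c3ccncc3)o2)c1` gives 16500 nM. Compound 1 `O=C(CSc1nnc(-c2ccncc2)o1)N/N=C/c1ccccc1` gives 16700 nM, and compound 2 `O=C(CSc1nnc(-c2ccncc2)o1)N/N=C/c1cccc(F)c1` gives 26700 nM. The three numbers lie close together: a 1.0-fold lower number from compound 1 to compound 3 (0.01 log units; within the scatter), a 1.6-fold lower number from compound 2 to compound 3 (0.21 log units; within the scatter), a 1.6-fold higher number from compound 1 to compound 2 (0.20 log units; within the scatter). Among the compounds with values here, compound 3 holds the lowest number of the three, yet no step separates it from the others beyond the scatter, so the three stand as equals on this read-out.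

Compound 4 `O=C(CSc1nnc(-c2ccncc2)o1)N/N=C/c1ccccc1[N+](=O)[O-]` is not yet measured. The change from compound 3 is 2-nitrophenyl in place of 3-methoxyphenyl on a carbon with a double bond to nitrogen. The steps measured so far on that same ring, hydrogen to fluoro, hydrogen to methoxy and fluoro to methoxy, all stayed within the scatter. The present change replaces the whole ring substituent pattern, a larger change than any step measured, so the expectation is less firm; still, with no change on that ring having moved the number beyond the scatter, a step in this assay of no more than the scatter is expected, in no fixed direction. Compound 4 is therefore estimated at 18000 nM, with a range from 7000 nM to 50000 nM. This estimate corresponds to an expected step of a 1.1-fold higher number from compound 3 to compound 4 (0.04 log units; within the scatter).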

Compound 4, half-maximal inhibitory concentration: 30700 nM
For compound 4 the middle estimate is 1.7-fold (0.23 log units) below the measured one; the range from low to high includes it.
By their numbers in this assay, from the lowest: compounds 3, 1, 2 and 4 (each within the scatter of the next).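

In this assay, 2-nitrophenyl on the carbon with a double bond to nitrogen brings a larger exchange than the earlier single-atom or methoxy steps, yet every new step stays within the scatter: a 1.8-fold higher number from compound 1 to compound 4 (0.26 log units; within the scatter) for nitro in place of hydrogen, a 1.1-fold higher number from compound 2 to compound 4 (0.06 log units; within the scatter) against 3-fluorophenyl, and a 1.9-fold higher number from compound 3 to compound 4 (0.27 log units; within the scatter) against 3-methoxyphenyl. The flat picture from the three earlier compounds therefore extends to a nitro-bearing ring with a different substitution pattern, and no step among these four compounds passes the scatter. No measurement available here bears on why the number holds across these rings.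

Open, from the compounds shown here alone, is whether an amine or a carboxylic acid on the phenyl ring would move the number beyond the scatter. Also open, going by these compounds, is whether a longer chain in place of the ring at this carbon would do so.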